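Azidomethyl Carbonyl Variant of the Weaker Anilide

The compounds below may be only part of what the source reports. "The series", "measured", "known", "first", "only" and "open" are said of these compounds alone.

Working notes on the amide series. Compound 1 `C/C=C/C(=O)N(Cc1cc(OC)c(OC)c(OC)c1)c1ccc(OC)c(O)c1` stands at the top of the two numbers measured: in a functional assay on HCT-116 cells (Homo sapiens) for inhibition, read by MTT assay, with a stated time of 48 h (a lower number here means a stronger inhibitor, a higher number a weaker inhibitor), compound 1 gives 8450 nM. Compound 2 `C=CC(=O)N(Cc1ccc(OC)c(O)c1)c1cc(OC)c(OC)c(OC)c1` differs from compound 1 in more than one place, so no single step can be read between them; in this assay compound 2 gives 98 nM, a far lower number than compound 1, beyond the scatter.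

Compound 3 `COc1ccc(N(Cc2cc(OC)c(OC)c(OC)c2)C(=O)CN=[N+]=[N-])cc1O` follows from compound 1 by one change: azidomethyl in place of prop-1-en-1-yl on a carbonyl carbon. Within the data shown here, no measured pair isolates this exchange, so the step is uncertain. Among the measured compounds shown here, the step of a 1.2-fold higher number from compound 1 to compound 3 (0.07 log units; within the scatter) is expected to stay within the usual scatter, in no clear direction, because compound 1 gives 8450 nM and nothing among the measured compounds bears on an azidomethyl group on the carbonyl carbon. Compound 3 is estimated at 10000 nM, with a range from 2500 nM to 40000 nM.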

Compound 3, half-maximal inhibitory concentration: 38800 nM
Compound 3: middle estimate off by 3.9-fold (0.59 log units), on the low side; measured number inside the range.
By their numbers in this assay, from the lowest: compound 2; then compound 1; then compound 3.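

In this assay, azidomethyl in place of prop-1-en-1-yl on a carbonyl carbon gives a 4.6-fold higher number from compound 1 to compound 3 (0.66 log units; beyond the scatter). Among these compounds, the earlier compounds offered no single step at this place, so this is the first sign that the group on the carbonyl carbon matters on the core of compound 1, with the number moving upward beyond the scatter. No measurement shown bears on what lies behind this step.

One exchange cannot tell whether the higher number goes with losing prop-1-en-1-yl or with bringing in azidomethyl, and an aminomethyl group or a longer alkyl chain on the same carbonyl carbon could help separate the two. Going by these compounds, it also remains open whether azidomethyl would move the number in the same direction on the core of compound 2.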